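Compound 3 to Compound 4: Methyl Becomes 4-Methoxyphenyl

The source may hold more compounds than are shown below. What is called first, only, known or untested is meant among the compounds shown, and "the series" means these compounds.

Three compounds share one core. Compound 1 `Cn1cnnc1SCC(=O)Nc1ccc(-c2nc(-c3ccccc3)c(-c3ccccc3)n2C)cc1` gives 3.2 ug/mL in a functional assay on MCF7 cells (Homo sapiens) for cytotoxicity, read by MTT assay, with a stated time of 24 h (a lower number here means a stronger inhibitor, a higher number a weaker inhibitor), and compound 2 `Cn1nnnc1SCC(=O)Nc1ccc(-c2nc(-c3ccccc3)c(-c3ccccc3)n2C)cc1` gives 4.5 ug/mL; the step of a 1.4-fold higher number from compound 1 to compound 2 (0.15 log units; within the scatter) stays within the scatter. Compound 3 `CCN1CCN(CC(=O)Nc2ccc(-c3nc(-c4ccccc4)c(-c4ccccc4)n3C)cc2)CC1` gives 80 ug/mL, the highest of the three numbers, with a 25-fold higher number from compound 1 to compound 3 (1.40 log units; beyond the scatter) and an 18-fold higher number from compound 2 to compound 3 (1.25 log units; beyond the scatter) both large. Compound 4 `COc1ccc(CN2CCN(CC(=O)Nc3ccc(-c4nc(-c5ccccc5)c(-c5ccccc5)n4C)cc3)CC2)cc1` differs from compound 3 by 4-methoxyphenyl in place of methyl on a saturated chain carbon bound to an amine nitrogen in a ring. Within the data shown here, no measured step touches this position; the two large steps concern the group on the saturated chain carbon bound to the carbonyl carbon, which compound 4 keeps unchanged. With nothing bearing directly on the change, the expected step of a 1.8-fold lower number from compound 3 to compound 4 (0.25 log units; within the scatter) in this assay is a modest one toward a lower number, not surely beyond the scatter. Compound 4 is therefore estimated at 45 ug/mL, between 15 ug/mL and 140 ug/mL.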

Compound 4, half-maximal inhibitory concentration: 80 ug/mL
For compound 4 the middle estimate is 1.8-fold (0.25 log units) below the measured one, within the range that was stated.
By their numbers in this assay, from the lowest: compounds 1 and 2 (each within the scatter of the next); then compounds 3 and 4 (each within the scatter of the next).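

In this assay, among these compounds, putting 4-methoxyphenyl in place of methyl on a saturated chain carbon bound to an amine nitrogen in a ring gives no change at the digits printed from compound 3 to compound 4 (within the scatter), the first reading at this position. Here a much larger group with an aromatic ring and a hydrogen-bond acceptor leaves the number unmoved. Nothing measured here accounts for this.

As far as these compounds go, whether a carboxylic acid or an amine at this position would move the number remains open. So does whether a longer chain would.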